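Compound 1 to compound 4: replacing chloro

A few compounds are considered here, and "the series" means these few. Any claim that something is new, unique, unknown or untested is made for them only; others in the source may bear on it.

In a functional assay on RKOp27 cells (Homo sapiens) for cytotoxicity, read by MTT assay, with a stated time of 3 days (a higher number here means a weaker inhibitor, a lower number a stronger inhibitor), compound 1 (`N#Cc1c(Cl)nc(SCc2nc3ccccc3[nH]2)nc1-c1ccccc1`) gives 4.38 nM. That lies within the scatter of compound 2 (`CNc1nc(SCc2nc3ccccc3[nH]2)nc(-c2ccccc2)c1C#N`) at 3.7 nM and of compound 3 (`CCNc1nc(SCc2nc3ccccc3[nH]2)nc(-c2ccccc2)c1C#N`) at 7.35 nM. Compound 4 (`N#Cc1c(Nc2nccs2)nc(SCc2nc3ccccc3[nH]2)nc1-c1ccccc1`) differs from compound 1 as follows: (1,3-thiazol-2-yl)amino in place of chloro on an aromatic carbon. Two measured steps replace the same chloro, a 1.2-fold lower number from compound 1 to compound 2 (0.07 log units; within the scatter) and a 1.7-fold higher number from compound 1 to compound 3 (0.22 log units; within the scatter). Both are within the scatter, as is a 2.0-fold higher number from compound 2 to compound 3 (0.30 log units; within the scatter). Neither methylamino nor ethylamino carries a ring, so the entering group goes beyond these measurements. No step beyond the scatter is expected, though with wider uncertainty. The estimated step is a 1.4-fold higher number from compound 1 to compound 4 (0.14 log units; within the scatter). Compound 4 is expected at 6 nM, with an estimated range of 2 nM to 20 nM.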

Compound 4, half-maximal inhibitory concentration: 3.2 nM
Beside the measured number, compound 4's estimate is 1.9-fold (0.27 log units) above it; low and high end bracket the measured number.
By their numbers in this assay, from the lowest: compounds 4, 2, 1 and 3 (each within the scatter of the next, the first and the last beyond it).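

Within the data shown here, at this aromatic carbon in this assay, (1,3-thiazol-2-yl)amino, the first entering group with a ring, can replace chloro without a step beyond the scatter (a 1.4-fold lower number from compound 1 to compound 4 (0.14 log units; within the scatter)), and the same holds for its replacement of methyl on the nitrogen (a 1.2-fold lower number from compound 2 to compound 4 (0.06 log units; within the scatter)). Only the replacement of ethyl on that nitrogen goes beyond the scatter, and modestly (a 2.3-fold lower number from compound 3 to compound 4 (0.36 log units; beyond the scatter)). No measurement at hand gives a cause for these steps. On these data alone, it remains open whether a phenyl or pyridyl group on this nitrogen, or a morpholine on this carbon, would keep the number in this range.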